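A few compounds are considered here, and "the series" means these few. Any claim that something is new, unique, unknown or untested is made for them only; others in the source may bear on it.

Measured so far:
compound 1 `CC(C)CCC(=O)N[C@@H](C(=O)N1CCC(c2ccc(Cl)cc2)CC1)C(C)C`
compound 2 `CC(C)C(NC(=O)Oc1ccccc1)C(=O)N1CCC(c2ccc(Cl)cc2)CC1`

In an assay on THP-1 cells for displacement of a labelled ligand from C-C chemokine receptor type 1 (Homo sapiens) (a higher number here means a weaker inhibitor, a lower number a stronger inhibitor), compound 1 gives 26 nM and compound 2 gives 265 nM. Compound 1 stands at the lower of the two numbers, and its gap to compound 2 lies beyond the scatter.

Compound 3 `Cc1ccccc1CCC(=O)N[C@@H](C(=O)N1CCC(c2ccc(Cl)cc2)CC1)C(C)C` differs from compound 1 in one place: 2-methylphenyl in place of isopropyl on a saturated chain carbon, two bonds along the chain from a carbonyl carbon. Within the data shown here, no measured pair shows this kind of change, so nothing sets its size. A small step toward lower numbers is expected, not clearly beyond the scatter. Compound 3 is estimated at 15 nM with a range of 4 nM to 60 nM. The expected step is a 1.7-fold lower number from compound 1 to compound 3 (0.24 log units; within the scatter).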

Compound 3, half-maximal inhibitory concentration: 19 nM
Compound 3: the middle estimate sits 1.3-fold (0.10 log units) below what was measured; measured number inside the range.
By their numbers in this assay, from the lowest: compounds 3 and 1 (each within the scatter of the next); then compound 2.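

In this assay, 2-methylphenyl in place of isopropyl on a saturated chain carbon, two bonds along the chain from a carbonyl carbon, gives a 1.4-fold lower number from compound 1 to compound 3 (0.14 log units; within the scatter) and leaves the two compounds inseparable. This position therefore takes one six-membered aromatic ring, with 7 heavy atoms in place of 3, with no change beyond the scatter. Nothing available bears on the reason for this result.

Still open, as far as these compounds go, is whether plain phenyl at this position reads the same as 2-methylphenyl. Also open, from the compounds shown here alone, is how an amine or a carboxylic acid in this place would read.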